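Replacing carboxy with 2H-tetrazol-5-yl in compound 2

A few compounds are considered here, and "the series" means these few. Any claim that something is new, unique, unknown or untested is made for them only; others in the source may bear on it.

In a functional assay (aorta) for antagonist activity, with Oryctolagus cuniculus as the target (on this read-out higher numbers stand for weaker inhibition and lower numbers for stronger inhibition), compound 1 (`CCCCc1nc(-c2ccccc2)c(C(=O)OCC)c(=O)n1Cc1ccc(-c2ccccc2C(=O)O)cc1`) gives 140 nM and compound 2 (`CCCCC1=NC(C)(C)C(C(=O)OCC)=C(Cl)N1Cc1ccc(-c2ccccc2C(=O)O)cc1`) gives 23 nM as the lower of the two numbers. That makes compound 2 the stronger inhibitor of this pair, by a gap beyond the usual scatter. The two differ in more than one place, so their gap says little about any single group. Compound 3 (`CCCCC1=NC(C)(C)C(C(=O)OCC)=C(Cl)N1Cc1ccc(-c2ccccc2-c2nn[nH]n2)cc1`) differs from compound 2 in one place, with 2H-tetrazol-5-yl in place of carboxy on an aromatic carbon. Among the compounds with values here, no measured pair shows this exchange, so what follows is a judgement and not a reading from the data. A moderate step toward stronger inhibition is expected in this assay and the estimated size is a 3.8-fold lower number from compound 2 to compound 3 (0.58 log units; beyond the scatter) as a middle figure. In this assay the estimated value for compound 3 is 6 nM within an expected range from 1.5 nM to 25 nM across repeat measurements.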

Compound 3, antagonist equilibrium constant: 24 nM
Beside the measured number, compound 3's estimate is 4.0-fold (0.60 log units) below it; the measured number falls inside the stated range.
By their numbers in this assay, from the lowest: compounds 2 and 3 (each within the scatter of the next); then compound 1.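

In this assay the exchange of carboxy for 2H-tetrazol-5-yl on this aromatic carbon gives a 1.0-fold higher number from compound 2 to compound 3 (0.02 log units; within the scatter) and so, at this place on the shared core, the two groups cannot be told apart on this read-out. This is the first pair shown that differs in one place only, which makes it the first direct reading of a single group: a five-membered aromatic ring with four nitrogens can stand where the carboxy stood with no change beyond the scatter. No information at hand explains why the two groups read alike.

Going by these compounds, whether a methyl ester or a sulfonamide at the same place would also match carboxy remains open. So does whether the same match would hold on the different core of compound 1.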